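The source may report more compounds than this note shows. Statements on the series, on what has been measured and on what is new or still open speak of the compounds shown alone.

Measured so far in a functional assay on HeLa cells (Homo sapiens) for antiproliferative activity, read by MTT assay, with a stated time of 72 h; on this read-out higher numbers stand for weaker inhibition and lower numbers for stronger inhibition:
- Compound 1 `COc1cc(-n2ncnc2-c2ccc(C)cc2)cc(OC)c1OC`: 250 nM
- Compound 2 `COc1ccc(-c2ncnn2-c2cc(OC)c(OC)c(OC)c2)cc1`: 280 nM
- Compound 3 `COc1cc(-n2ncnc2-c2ccc(Cl)cc2)cc(OC)c1OC`: > 10000 nM, a limit of the assay and not a number

Compound 3 stands at the limit of > 10000 nM in this assay, at which 1 of the 3 values shown sits. Compound 4 `COc1cc(-n2ncnc2-c2ccc(OC(F)(F)F)cc2)cc(OC)c1OC` differs from it by trifluoromethoxy in place of chloro on an aromatic carbon, para to a large group (trifluoromethoxy in place of chloro on an aromatic carbon). For the measured compounds named here, three measured steps concern this same place. The first is a 1.1-fold higher number from compound 1 to compound 2 (0.05 log units; within the scatter), and the other two are large: an at least 40-fold higher number from compound 1 to compound 3 (1.60 log units; beyond the scatter) and an at least 35-fold higher number from compound 2 to compound 3 (1.55 log units; beyond the scatter). Together they show that a change here can move the number a long way, but no measured compound carries trifluoromethoxy. A move towards a lower number than that of compound 3 is therefore expected, probably smaller than those two large steps, and compound 4 may well stay at the limit. The expected step is an at least 3.3-fold lower number from compound 3 to compound 4 (0.52 log units; beyond the scatter). For compound 4 the estimated value is 3000 nM, with an expected range from 250 nM to 10000 nM.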

Compound 4, half-maximal inhibitory concentration: > 10000 nM
Compound 4: a limit, no number; the forecaster's own chance of this, stated with the estimate: 35%; middle value at least 3.3-fold (0.52 log units) away from the limit.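

In this assay, for the compounds shown here, the earlier compounds showed a large loss only with chloro; trifluoromethoxy now gives a second large loss at this place, with an at least 40-fold higher number from compound 1 to compound 4 (1.60 log units; beyond the scatter). Replacing the methyl of the methoxy group with trifluoromethyl, while the oxygen stays in place, is enough for an at least 35-fold higher number from compound 2 to compound 4 (1.55 log units; beyond the scatter), so a methoxy-like link through oxygen does not by itself keep the number low. Among these four compounds, methyl and methoxy give measurable values, whereas chloro and trifluoromethoxy both leave the read-out at a limit of the assay, not a number: the limit of > 10000 nM in this assay, at which 2 of the 4 values shown sit.

The step between compound 3 and compound 4 cannot be read, so the two groups cannot be ranked. From the compounds shown here alone, whether an amine, a hydroxyl or an ethyl at this place would keep the number near that of compound 1 remains open.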